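Hydrazide in Place of the Acid on a Saturated Chain

The source may hold more compounds than are shown below. What is called first, only, known or untested is meant among the compounds shown, and "the series" means these compounds.

Three measured compounds share one core and differ only in the side chain:
compound 1, `O=C(O)CCc1ccncc1-c1ccc2ccccc2c1`, gives 50.5 nM in an assay on a protein complex for inhibition of CDK8/Cyclin C (Homo sapiens), with a stated time of 1 h; a higher number here means a weaker inhibitor, a lower number a stronger inhibitor;
compound 2, `COC(=O)/C=C/c1ccncc1-c1ccc2ccccc2c1`, gives 40.6 nM in this assay;
compound 3, `O=C(O)/C=C/c1ccncc1-c1ccc2ccccc2c1`, gives 5 nM in this assay.

Compound 3 has the lowest number of the three. Its nearest neighbour is compound 2, and the gap is an 8.1-fold lower number from compound 2 to compound 3 (0.91 log units; beyond the scatter); the larger gap is a 10-fold lower number from compound 1 to compound 3 (1.00 log units; beyond the scatter), both beyond the scatter. The step from compound 1 to compound 2, a 1.2-fold lower number from compound 1 to compound 2 (0.09 log units; within the scatter), lies within the scatter.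

Compound 4, `NNC(=O)CCc1ccncc1-c1ccc2ccccc2c1`, has not yet been measured in this assay. Against compound 3 the change is 2-(aminocarbamoyl)ethyl in place of 2-carboxyethenyl on an aromatic carbon. Within the data shown here, two measured steps bear on it. The saturated chain of compound 4 matches compound 1, and the step from compound 1 to compound 3 shows that going from that chain to the unsaturated acid lowered the number by a 10-fold lower number from compound 1 to compound 3 (1.00 log units; beyond the scatter). The loss of the free acid recalls the step from compound 2 to compound 3, where restoring the acid gave an 8.1-fold lower number from compound 2 to compound 3 (0.91 log units; beyond the scatter). Both changes in compound 4 run opposite to those steps, so a higher number is expected for compound 4, with a step of about a 24-fold higher number from compound 3 to compound 4 (1.38 log units; beyond the scatter). Compound 4 is therefore estimated at 120 nM, in the range 35 nM to 400 nM.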

Compound 4, half-maximal inhibitory concentration: 7.7 nM
Compound 4: the middle estimate sits 16-fold (1.19 log units) above what was measured; measured number below the stated range.
By their numbers in this assay, from the lowest: compounds 3 and 4 (each within the scatter of the next); then compounds 2 and 1 (each within the scatter of the next).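

Among these compounds, on the saturated chain, the swap of aminoamino for hydroxy on the carbonyl carbon gave a 6.6-fold lower number from compound 1 to compound 4 (0.82 log units; beyond the scatter) in this assay, which shows that a free acid is not required at this position, a point the earlier compounds could not settle, as there the ester on the unsaturated chain trailed the acid. The comparison with the unsaturated acid, a 1.5-fold higher number from compound 3 to compound 4 (0.19 log units; within the scatter), puts the two side chains level, so a saturated chain can match the unsaturated acid when it carries the hydrazide, and the comparison with the unsaturated ester, a 5.3-fold lower number from compound 2 to compound 4 (0.72 log units; beyond the scatter), shows that the hydrazide on the saturated chain also outdoes that ester. Nothing given here accounts for why the hydrazide restores what the saturated acid lacks.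

The compounds shown leave open whether a hydrazide on the unsaturated chain would lower the number further or add nothing, since the chain and the end group change together between compound 3 and compound 4. They also leave open whether a primary amide, a hydroxamic acid or a longer chain carrying the hydrazide would hold the same level.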